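The compounds below may be only part of what the source reports. "The series", "measured", "known", "first", "only" and "open" are said of these compounds alone.

Of the compounds shown here, three have so far been measured in a functional assay on MCF7 cells (Homo sapiens) for inhibition, read by MTT assay, with a stated time of 48 h, tested at 10 uM; on this read-out higher numbers stand for more inhibition of growth at the one concentration tested and lower numbers for less inhibition of growth. Compound 1 `Cc1oc2c([C@H]3CCN(C)C[C@H]3O)c(O)cc(O)c2c(=O)c1C(O)c1ccc(Cl)cc1` gives 6%, and compound 2 `Cc1oc2c([C@H]3CCN(C)C[C@H]3O)c(O)cc(O)c2c(=O)c1C(O)c1ccc(F)cc1` gives 9%. The two differ by chloro in place of fluoro on an aromatic carbon, a step of a number 3 percentage points lower from compound 2 to compound 1 (within the scatter). Compound 3 `CN1CC[C@H](c2c(O)cc(O)c3c(=O)cc(/C=C/c4ccccc4F)oc23)[C@H](O)C1` gives 62% in this assay; the difference between its core and the core of compound 2 is not broken down here. Compound 4 `CN1CC[C@H](c2c(O)cc(O)c3c(=O)cc(/C=C/c4ccccc4Cl)oc23)[C@H](O)C1`, not yet measured, differs from compound 3 by chloro in place of fluoro on an aromatic carbon. For the measured compounds named here, this is the same kind of change as the one from compound 2 to compound 1, though the place is not identical: there the group sits para to a large group, here ortho to a large group. The earlier step, a number 3 percentage points lower from compound 2 to compound 1 (within the scatter), was small. On that basis a similarly small step is expected, a number 2 percentage points lower from compound 3 to compound 4 (within the scatter). Compound 4 is therefore estimated at 60%, most likely between 42% and 75%.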

Compound 4, percent growth inhibition at one concentration: 63%
Beside the measured number, compound 4's estimate is 3 percentage points below it, within the range that was stated.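

In this assay the new step, chloro in place of fluoro on an aromatic carbon, is a number 1 percentage points higher from compound 3 to compound 4 (within the scatter), so compound 3 and compound 4 cannot be told apart. Set beside the earlier step, this exchange reads the same on both cores: the same change on two cores in this assay, a number 3 percentage points lower (within the scatter) from compound 2 to compound 1 and a number 1 percentage points higher (within the scatter) from compound 3 to compound 4, 4 percentage points apart, within the scatter of two such steps This rests on only two pairs of compounds tested at one concentration, so it does not show that the exchange would behave this way on any other core, nor why it makes so little difference here.

The compounds shown leave open what a different group at this place on the ring, such as methoxy, nitrile or an amine, would do. From the compounds shown here alone, it also remains open which part of the difference between the two cores separates compound 2 from compound 3.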